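The source may hold more compounds than are shown below. What is called first, only, known or untested is meant among the compounds shown, and "the series" means these compounds.

Measured so far in a functional assay on MDA-MB-468 cells (Homo sapiens) for antiproliferative activity, read by sulforhodamine B assay, with a stated time of 48 h (on this read-out lower numbers stand for stronger inhibition and higher numbers for weaker inhibition), for the series
compound 1 `O=C(NCCCNc1cc(-c2cn(-c3ccccc3)nc2-c2cccc(O)c2)ccn1)Nc1ccc(F)cc1` gives 1180 nM
compound 2 `O=C(NCCCNc1cc(-c2cn(-c3ccccc3)nc2-c2cccc(O)c2)ccn1)Nc1cccc(C(F)(F)F)c1` gives 1610 nM

For the measured compounds named here, compound 1 stands level with compound 2 within the scatter, and these are the only two numbers available. Going by the values given here, the one measured step is a 1.4-fold higher number from compound 1 to compound 2 (0.13 log units; within the scatter) for 3-(trifluoromethyl)phenyl in place of 4-fluorophenyl on an amide-type nitrogen.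

Compound 3 `COc1cccc(-c2nn(-c3ccccc3)cc2-c2ccnc(NCCCNC(=O)Nc3ccc(F)cc3)c2)c1` has not yet been measured. Against compound 1 it carries methyl in place of hydrogen on an oxygen on an aromatic ring as the change from hydroxy to methoxy, or 3-hydroxyphenyl to 3-methoxyphenyl. Among the compounds with values here, the measured step lies at a different place and no measured pair tests this oxygen, so it offers only a weak guide. No step beyond the scatter is expected, and the direction is not secure. The expected size is a 1.4-fold higher number from compound 1 to compound 3 (0.16 log units; within the scatter) on this estimate. For compound 3 the estimated value is 1700 nM with an expected range from 600 nM to 5000 nM in this read-out.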

Compound 3, half-maximal inhibitory concentration: 4830 nM
The estimate for compound 3 lay 2.8-fold (0.45 log units) below the measured number, within the range that was stated.
By their numbers in this assay, from the lowest: compounds 1 and 2 (each within the scatter of the next); then compound 3.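

In this assay, for the compounds shown here, methyl in place of hydrogen on the oxygen of the 3-hydroxyphenyl group gives a 4.1-fold higher number from compound 1 to compound 3 (0.61 log units; beyond the scatter), the only step so far that lies beyond the scatter. This oxygen is therefore a place where the read-out responds to a small change, unlike the one measured change on the amide-type nitrogen, and among these two compounds the hydroxy form carries the lower number. No measurement on hand bears on why the number rises with the methoxy group.

On these data alone, it remains open whether an amine, a fluorine or a carboxylic acid in place of the hydroxy would stand closer to compound 1 or to compound 3. Also open, as far as these compounds go, is whether the methoxy step carries over to compounds bearing the 3-(trifluoromethyl)phenyl group of compound 2.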